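The compounds below may be only part of what the source reports. "The series", "measured", "known", "first", "only" and "open" are said of these compounds alone.

Compound 1 `CCNC(=O)CCCOc1ccc(-c2nc3ncccn3c2NC2CCCCC2)cc1`: in a toxicity assay on A549 cells (Homo sapiens) for cytotoxicity, read by luminescence and CellTiter-Glo, with a stated time of 48 h (a higher number here means that more compound is tolerated, a lower number that less compound is tolerated), compound 1 gives > 100000 nM, which is a limit of the assay rather than a number.
Compound 2 `Clc1ccc(-c2nc3ncccn3c2NC2CCCCC2)cc1`: in this assay compound 2 gives > 100000 nM, also a limit of the assay.

Compound 2 therefore stands at the limit, where both measured values sit: the limit of > 100000 nM in this assay, at which 2 of the 2 values shown sit. Within the data shown here, the only measured step, a step that the two limits leave unreadable from compound 1 to compound 2, is unreadable, so it offers no size to build on. Compound 3 `Oc1ccc(-c2nc3ncccn3c2NC2CCCCC2)cc1` differs from compound 2 by hydroxy in place of chloro on an aromatic carbon. With no readable step bearing on this change, the expected step in this assay is none beyond the scatter, and compound 3 is expected to sit at the limit as well, giving a number no higher from compound 2 to compound 3 (the limit leaves the size open). Compound 3 is estimated at 100000 nM, with a range from 30000 nM to 300000 nM.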

Compound 3, half-maximal cytotoxic concentration: > 100000 nM
Compound 3 gave a limit, no number; the forecaster's own chance of this, stated with the estimate: 85%; the middle value lies on the limit itself.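

No step can be read among compound 1, compound 2 and compound 3, since each result is a limit of the assay rather than a number: the limit of > 100000 nM in this assay, at which 3 of the 3 values shown sit.

The compounds shown leave open whether chloro, hydroxy or 3-(ethylcarbamoyl)propoxy on the aromatic ring changes how much compound is tolerated.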